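The source may report more compounds than this note shows. Statements on the series, on what has been measured and on what is new or still open speak of the compounds shown alone.

Compound 1 `Cc1cccc2nc(N3CCN(C)CC3)oc12` gives 5.48 in a functional assay on ileum (strain Hartley) for agonist activity at 5-hydroxytryptamine receptor 3A (Cavia porcellus); on this read-out lower numbers stand for lower potency and higher numbers for higher potency (the scale is a negative logarithm). Compound 2 `CC(C)c1cccc2nc(N3CCN(C)CC3)oc12` gives only < 4 in this assay, a limit of the assay rather than a number, and it therefore sits at the limit of < 4 in this assay, at which 1 of the 2 values shown sits. Going by the values given here, the one measured step, a number at least 1.48 log units lower from compound 1 to compound 2 (beyond the scatter), is the sole guide. Compound 3 `CN1CCN(c2nc3cccc(Cl)c3o2)CC1` differs from compound 2 by chloro in place of isopropyl on an aromatic carbon, replacing a group of three heavy atoms with one of a single heavy atom. A recovery is expected, with the step of a number at least 1.00 log units higher from compound 2 to compound 3 (beyond the scatter) estimated upward. Compound 3 is expected to reach about 5, within 4 to 6.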

Compound 3, negative logarithm of the half-maximal effective concentration: 5.5
Compound 3: the middle estimate sits 0.50 log units below what was measured; low and high end bracket the measured number.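

Chloro in place of isopropyl on this aromatic carbon brings activity back in this assay, with a number at least 1.50 log units higher from compound 2 to compound 3 (beyond the scatter). Compound 2 remains a limit of the assay and not a number: the limit of < 4 in this assay, at which 1 of the 3 values shown sits. Chloro and methyl at this place are not told apart, with a number 0.02 log units higher from compound 1 to compound 3 (within the scatter), so among the three groups shown the loss goes with isopropyl alone. Left open is how ethyl, methoxy or an amino group on this aromatic carbon would read, and whether plain hydrogen there would hold the level of compound 1 and compound 3.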